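Methylating the hydroxy group of compound 3

This account rests on a few compounds, and the source may have more. Where it says the series, first, only, none or still open, it means among the compounds named here.

In a functional assay on PANC-1 cells (Homo sapiens) for cytotoxicity, read by MTT assay, with a stated time of 68 h (a higher number here means a weaker inhibitor, a lower number a stronger inhibitor), compound 1 `O=C(/C=C/c1cccc(OCc2ccccc2)c1)c1ccc([N+](=O)[O-])cc1` gives 25400 nM and compound 2 `O=C(/C=C/c1cccc(OCc2ccccc2)c1)c1ccc(Cl)cc1Cl` gives 27200 nM, and a 1.1-fold higher number from compound 1 to compound 2 (0.03 log units; within the scatter) separates them. Compound 3 `O=C(/C=C/c1cccc(OCc2ccccc2)c1)c1ccc(O)cc1` has the lowest number of the three, at 2600 nM. The next structure is compound 4 `COc1ccc(C(=O)/C=C/c2cccc(OCc3ccccc3)c2)cc1`, which has methyl in place of hydrogen on an oxygen on an aromatic ring, turning hydroxy to methoxy: methyl in place of hydrogen on an oxygen on an aromatic ring.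

Within the data shown here, no measured step makes this exact change. The closest evidence is a 9.8-fold lower number from compound 1 to compound 3 (0.99 log units; beyond the scatter) and a 10-fold lower number from compound 2 to compound 3 (1.02 log units; beyond the scatter), both of which arrive at the 4-hydroxyphenyl compound. Among the measured compounds shown here, these steps replace a whole substituent or ring, so they indicate only that the number is sensitive at this part of the structure. With the hydroxy hydrogen gone, a move back toward higher numbers is expected, but probably only part of the way. The expected change is a 3.1-fold higher number from compound 3 to compound 4 (0.49 log units; beyond the scatter). For compound 4 the estimate is 8000 nM, with an expected range of 2500 nM to 25000 nM.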

Compound 4, half-maximal inhibitory concentration: 44300 nM
Beside the measured number, compound 4's estimate is 5.5-fold (0.74 log units) below it; the measured number lies above the stated range.
By their numbers in this assay, from the lowest: compound 3; then compounds 1, 2 and 4 (each within the scatter of the next).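

In this assay, among these compounds, methyl in place of hydrogen on the oxygen alone gives a large step (a 17-fold higher number from compound 3 to compound 4 (1.23 log units; beyond the scatter)), so a change of a single hydrogen at this position is enough to lose the low number that earlier comparisons showed only through whole-substituent replacements. Compound 4 does not separate from the other two compounds lacking the hydroxy group (methoxy in place of nitro: a 1.7-fold higher number from compound 1 to compound 4 (0.24 log units; within the scatter); 4-methoxyphenyl in place of 2,4-dichlorophenyl: a 1.6-fold higher number from compound 2 to compound 4 (0.21 log units; within the scatter)), and among these four compounds only compound 3, the sole hydroxy compound, stands apart. Nothing on hand accounts for the size of this step.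

From the compounds shown here alone, whether the hydroxy group is the only substituent at this position that keeps the number low remains open. An amine or a carboxylic acid in its place would address that, while an ethyl or longer chain on the oxygen would show whether methoxy already marks the full loss.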